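This account rests on a few compounds, and the source may have more. Where it says the series, first, only, none or still open, it means among the compounds named here.

In a functional assay on U-251 cells (Homo sapiens) for cytotoxicity (a higher number here means a weaker inhibitor of growth, a lower number a stronger inhibitor of growth), compound 1 `COc1ccc(C2=C(c3ccc(SC)cc3)CC3CCCN3C2=O)cc1OC(=O)C1CCCN1C(=O)OC(C)(C)C` gives 2000 nM, while compound 2 `CSc1ccc(C2=C(c3ccc(O)c(O)c3)C(=O)N3CCCC3C2)cc1` gives 30000 nM. Compound 2 therefore holds the higher of the two numbers, which makes it the weaker inhibitor of growth, and the gap lies beyond the usual scatter. Compound 3 `CSc1ccc(C2=C(c3ccc(SC)cc3)C(=O)N3CCCC3C2)cc1` differs from compound 2 in one place, with 4-(methylsulfanyl)phenyl in place of 3,4-dihydroxyphenyl on a double-bonded ring carbon. Going by the values given here, no measured pair shows this exact change, so any forecast is loose. Compound 1 has no 3,4-dihydroxyphenyl group and sits at 2000 nM, so a moderate move toward a lower number, and thus stronger growth inhibition, is expected. The expected size of this move is a 3.8-fold lower number from compound 2 to compound 3 (0.57 log units; beyond the scatter). The estimate for compound 3 is 8000 nM, with an expected range of 2000 nM to 30000 nM.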

Compound 3, concentration for 50% growth inhibition: 5000 nM
Compound 3: middle estimate off by 1.6-fold (0.20 log units), on the high side; measured number inside the range.
By their numbers in this assay, from the lowest: compound 1; then compound 3; then compound 2.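

In this assay, putting 4-(methylsulfanyl)phenyl in place of 3,4-dihydroxyphenyl on the double-bonded ring carbon gives a 6.0-fold lower number from compound 2 to compound 3 (0.78 log units; beyond the scatter) and this modest step lies beyond the scatter. Going by these compounds alone, it is the only direct comparison at this position, and it shows that the 3,4-dihydroxyphenyl group is not required for growth inhibition on this core, since the compound whose group there has no hydrogen-bond donors is the stronger inhibitor of growth. No measurement here explains why the number falls.

This single swap removes two hydroxyl groups and adds a methylsulfanyl group at once, so the compounds shown cannot separate those two parts of the change. A plain phenyl ring, or a phenyl ring bearing one hydroxyl group or an amine, would help tell them apart.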